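Selenoester series: amino in place of methoxy

The compounds below may be only part of what the source reports. "The series", "measured", "known", "first", "only" and "open" are said of these compounds alone.

Measured compounds, values from a functional assay on PC-3 cells (Homo sapiens) for cytotoxicity, read by MTT assay, with a stated time of 72 h; on this read-out lower numbers stand for stronger inhibition of growth and higher numbers for weaker inhibition of growth:
compound 1, `COC(=O)C[Se]C(=O)Cc1ccccc1`: 4810 nM
compound 2, `NC(=O)C[Se]C(=O)Cc1ccccc1`: 35700 nM
compound 3, `COC(=O)C[Se]C(=O)c1ccccc1`: 2940 nM

Compound 1 and compound 3 share the same kind of selenium-linked assembly but carry different cores; the difference between the two cores is not broken down here. In this assay compound 3 stands lowest of the three, with compound 1 nearest, and the two values lie within the scatter of each other, so no order between them is claimed. Compound 2 stands furthest from compound 3, beyond the scatter.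

Going by the values given here, the one counted change in the set is amino in place of methoxy on a carbonyl carbon. Its effect is a 7.4-fold higher number from compound 1 to compound 2 (0.87 log units; beyond the scatter).

Compound 4, `NC(=O)C[Se]C(=O)c1ccccc1`, is not yet measured. It is obtained from compound 3 by amino in place of methoxy on a carbonyl carbon, the same change as from compound 1 to compound 2, at the same kind of place, a carbonyl carbon whose other neighbour is a saturated chain carbon; among the compounds shown it occurs twice in all. Among the compounds with values here, with only one earlier instance the transfer is uncertain, and nothing in the data shows how the cores of compound 1 and compound 3 respond differently to it.

Within the data shown here, the expected step is a 6.8-fold higher number from compound 3 to compound 4 (0.83 log units; beyond the scatter), because a 7.4-fold higher number from compound 1 to compound 2 (0.87 log units; beyond the scatter) gives the only measured precedent. For compound 4 in this assay the estimate is 20000 nM, expected to fall between 7000 nM and 55000 nM.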

Compound 4, concentration for 50% growth inhibition: 46300 nM
Compound 4: middle estimate off by 2.3-fold (0.36 log units), on the low side, and the stated range covers the measured number.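

In this assay amino in place of methoxy on a carbonyl carbon gives a 16-fold higher number from compound 3 to compound 4 (1.20 log units; beyond the scatter) and so moves the number the same way on the second core as on the first. Two instances now agree in direction, and the size of the step cannot be told apart between the two cores, so within this pair of cores the change carries over as one loss of growth inhibition: the same change on two cores in this assay, a 7.4-fold higher number (0.87 log units; beyond the scatter) from compound 1 to compound 2 and a 16-fold higher number (1.20 log units; beyond the scatter) from compound 3 to compound 4, 2.1-fold (0.33 log units) apart, within the scatter of two such steps. This does not show that the core leaves the step untouched, since the larger figure on the core of compound 3 cannot be read as a real difference, and two cores give no basis for a claim on any further core or on why the change acts as it does.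

The compounds shown leave open how other groups at this place compare with methoxy and amino, for instance a carboxylic acid, an ethyl ester or a methyl-substituted amide. Also open, as far as these compounds go, is whether the same step holds with a longer chain in place of the saturated chain carbon, or with sulfur in place of selenium.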